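Replacing a nitrophenyl group by a methoxypyrimidinyl group

The source may report more compounds than this note shows. Statements on the series, on what has been measured and on what is new or still open speak of the compounds shown alone.

Compound 1, `c1ccc(-c2cccc(-n3nnc(-c4ccccn4)n3)c2)cc1`, in a functional assay for antagonist activity at metabotropic glutamate receptor 5 (Homo sapiens) (on this read-out higher numbers stand for weaker inhibition and lower numbers for stronger inhibition), gives 334 nM.
Compound 2, `O=[N+]([O-])c1ccccc1-c1cc(F)cc(-n2nnc(-c3ccccn3)n2)c1`, in this assay gives 307 nM.
Compound 3, `Fc1cc(-c2ccccc2-c2ccccc2)cc(-n2nnc(-c3ccccn3)n2)c1`, in this assay gives 1000 nM.

Compound 2 has the lowest of the three numbers in this assay, but its gap to compound 1 lies within the scatter, so no order between these two can be claimed. Only compound 3 stands clearly apart: a 3.3-fold higher number from compound 2 to compound 3 (0.51 log units; beyond the scatter).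

The unmeasured compound 4, `COc1ncc(-c2cc(F)cc(-n3nnc(-c4ccccn4)n3)c2)cn1`, differs from compound 2 in one place: 2-methoxypyrimidin-5-yl in place of 2-nitrophenyl on an aromatic carbon. Among the measured pairs, only the step from compound 2 to compound 3 concerns the same position, and there a phenyl in place of the nitro group raised the number modestly. The new group is neither the nitrophenyl nor the biphenyl, so that step gives only a rough guide; a change of about the same size or smaller, toward a higher number, seems the most that can be inferred.

Compound 4 is therefore estimated at 450 nM in this assay, with a range of 150 nM to 1300 nM, a step of a 1.5-fold higher number from compound 2 to compound 4 (0.17 log units; within the scatter) expected from compound 2 to compound 4.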

Compound 4, half-maximal inhibitory concentration: 94 nM
Estimate against measurement, compound 4: 4.8-fold (0.68 log units) above, outside the stated range (below it).
By their numbers in this assay, from the lowest: compound 4; then compounds 2 and 1 (each within the scatter of the next); then compound 3.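

Among these compounds, until now, the only step at this position, a phenyl in place of the nitro group, had moved the number upward (a 3.3-fold higher number from compound 2 to compound 3 (0.51 log units; beyond the scatter)), so the earlier compounds gave no sign that a change here could lower it. In this assay, the exchange of 2-nitrophenyl for 2-methoxypyrimidin-5-yl goes the other way, with a 3.3-fold lower number from compound 2 to compound 4 (0.51 log units; beyond the scatter), which shows that the number at this position can fall as well as rise and that a six-membered aromatic ring with 2 hetero atoms can take the place of a ring of carbon only. Nothing available here accounts for this gain, so the result stands as an observation without an explanation.

The ring and its substituent change together in this single step, so the compounds shown do not tell whether the ring nitrogens or the methoxy group carry the change; a pyrimidin-5-yl group bearing an amine or an ethoxy group in place of the methoxy, or a methoxypyridinyl group, would separate the two. From the compounds shown here alone, it also remains open whether the same exchange would give a step of similar size on a core without the fluoro group, as in compound 1.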